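A few compounds are considered here, and "the series" means these few. Any claim that something is new, unique, unknown or untested is made for them only; others in the source may bear on it.

In a functional assay on SW-620 cells (Homo sapiens) (a lower number here means a stronger inhibitor of growth, a higher number a weaker inhibitor of growth), compound 1 (`O=S(=O)(/C=C/c1ccc(Cl)cc1Cl)Cc1ccc(Nc2ncnc3cc(Cl)ccc23)cc1`) has > 100000 nM as a limit, not a number. Compound 2 (`O=S(=O)(/C=C/c1ccc(C(F)(F)F)cc1F)Cc1ccc(Nc2ncnc3cc(Cl)ccc23)cc1`) likewise has > 100000 nM as a limit. The evidence from these two amounts to the limit of > 100000 nM in this assay, at which 2 of the 3 values shown sit, and gives no number to work from. Among the measured compounds shown here, compound 3 (`COc1cc2ncnc(Nc3ccc(CS(=O)(=O)/C=C/c4ccc(Cl)cc4Cl)cc3)c2cc1OC`) gives 2000 nM and holds the only number in the set.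

Compound 4 (`COc1cc2ncnc(Nc3ccc(CS(=O)(=O)/C=C/c4ccc(Br)cc4)cc3)c2cc1OC`) differs from compound 3 by 4-bromophenyl in place of 2,4-dichlorophenyl on a double-bonded chain carbon bound to a double-bonded chain carbon and keeps the core of compound 3. For the measured compounds named here, the only measured step at this place is a step that the two limits leave unreadable from compound 1 to compound 2 and offers no guide to size or direction. Both of its compounds also carry a different core from compound 3.

With that step unreadable, the expectation rests on compound 3 at 2000 nM alone, and no step beyond the usual scatter is expected in this assay in either direction. The expected change is a 1.5-fold higher number from compound 3 to compound 4 (0.18 log units; within the scatter) and remains a loose estimate. Compound 4 is estimated at 3000 nM (expected range 500 nM to 20000 nM).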

Compound 4, concentration for 50% growth inhibition: 5000 nM
Compound 4: middle estimate off by 1.7-fold (0.22 log units), on the low side; measured number inside the range.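

Among the compounds shown here, with the core of compound 3 held, 4-bromophenyl in place of 2,4-dichlorophenyl gives the first readable step at this place in this assay: a 2.5-fold higher number from compound 3 to compound 4 (0.40 log units; beyond the scatter). The step is modest, and both compounds keep a measured number, so on this core the place accepts more than one halogen-bearing phenyl group, with 4-bromophenyl the weaker inhibitor of growth of the two. The earlier step at this place, on a different core, cannot be read: the limit of > 100000 nM in this assay, at which 2 of the 4 values shown sit.

On these data alone, this single step changes both halogens at once, so the share of each remains open, and 4-chlorophenyl on the core of compound 3 would separate them. Also open is how this place responds to a phenyl group carrying an amine or a carboxylic acid, since every group shown here carries only halogen or trifluoromethyl.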